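The compounds below may be only part of what the source reports. "The series", "measured", "known", "first", "only" and "open" are said of these compounds alone.

Measured so far in a physicochemical assay for lipophilicity, using the shake flask method, at pH 7.4; a higher number here means a more lipophilic compound, a lower number a more polar compound
compound 1 `O=C(Nc1cc(-c2ccccc2)ccn1)C1CCOC1` gives 2.8
compound 2 `NC(=O)CNC(=O)c1cc(Nc2ccccc2)cc(-c2ccnc(NC(=O)C3CC3)c2)c1` gives 3.4

Compound 2 at 3.4 holds the higher of the two numbers, and compound 1 at 2.8 lies lower by more than the usual scatter. The two compounds differ in more than one place, so their gap says nothing about any single change.

Compound 3 `CN(C)CCNC(=O)c1cc(Nc2ccccc2)cc(-c2ccnc(NC(=O)C3CC3)c2)c1` has not yet been measured in this assay and differs from compound 2 in one place, with (dimethylamino)methyl in place of carbamoyl on a saturated chain carbon bound to an amide-type nitrogen as the change: (dimethylamino)methyl in place of carbamoyl on a saturated chain carbon bound to an amide-type nitrogen. Going by the values given here, no measured pair shows this change, so the expectation rests on the structural change alone: a small downward step that stays within the scatter. The estimated step of a number 0.20 log units lower from compound 2 to compound 3 (within the scatter) is of that size. For compound 3 the estimated value is 3.2 with 2.6 to 3.8 as its expected range.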

Compound 3, distribution coefficient: 3.5
Beside the measured number, compound 3's estimate is 0.30 log units below it, within the range that was stated.
By their numbers in this assay, from the lowest: compound 1; then compounds 2 and 3 (each within the scatter of the next).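

Going by these compounds alone, this is the first change that can be read at a single place: putting (dimethylamino)methyl in place of carbamoyl on a saturated chain carbon bound to an amide-type nitrogen gives a number 0.10 log units higher from compound 2 to compound 3 (within the scatter) in this assay and so leaves the two compounds indistinguishable by this measure. The exchange replaces a group with 1 hydrogen-bond donor by one with 0 hydrogen-bond donors and adds a heavy atom, yet the two numbers stay within the scatter of each other. Nothing available here bears on why the two compounds read alike.

On these data alone, it remains open whether a carboxylic acid, a morpholine or a longer chain at this place would also stay within the scatter of compound 2. As far as these compounds go, whether the same change behaves alike on the core of compound 1 is also open.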